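Chloro in place of hydroxy on the 3-hydroxyphenyl group

The compounds below may be only part of what the source reports. "The series", "measured", "known", "first", "only" and "open" are said of these compounds alone.

Values in a functional assay on HepG2 cells (Homo sapiens) for cytotoxicity, read by MTT assay, with a stated time of 48 h (a higher number here means a weaker inhibitor, a lower number a stronger inhibitor), so far:

compound 1 `O=C1/C(=C\c2ccc(O)c(O)c2)S/C(=N/c2ccccc2)N1Cc1ccncc1` gives 16200 nM
compound 2 `COc1ccc(/C=C2/S/C(=N/c3ccccc3)N(Cc3ccncc3)C2=O)cc1OC` gives 28900 nM
compound 3 `O=C1/C(=C\c2cccc(O)c2)S/C(=N/c2ccccc2)N1Cc1ccncc1` gives 17600 nM

Compound 3 at 17600 nM cannot be told apart from the other two measured compounds. The step of a 1.1-fold higher number from compound 1 to compound 3 (0.04 log units; within the scatter) and the step of a 1.6-fold lower number from compound 2 to compound 3 (0.22 log units; within the scatter) both stay within the scatter.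

Compound 4 `O=C1/C(=C\c2cccc(Cl)c2)S/C(=N/c2ccccc2)N1Cc1ccncc1` differs from compound 3 by a single exchange chloro in place of hydroxy on an aromatic carbon and carries chloro in place of hydroxy on an aromatic carbon. For the measured compounds named here, no measured step brings in chloro, so the data hold no direct precedent. The nearest guides are the changes on the same substituted phenyl group, which also include the step of a 1.8-fold higher number from compound 1 to compound 2 (0.25 log units; within the scatter) and which all stay within the scatter. No step beyond the scatter is therefore expected in this assay and no direction is favoured. The expected step is a 1.1-fold lower number from compound 3 to compound 4 (0.04 log units; within the scatter) and remains an estimate. For compound 4 the estimated value is 16000 nM with an expected range from 7000 nM to 35000 nM.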

Compound 4, half-maximal inhibitory concentration: 28900 nM
For compound 4 the middle estimate is 1.8-fold (0.26 log units) below the measured one, within the range that was stated.
By their numbers in this assay, from the lowest: compounds 1, 3, 2 and 4 (each within the scatter of the next).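

In this assay, the exchange of hydroxy for chloro on the six-membered aromatic ring gives a 1.6-fold higher number from compound 3 to compound 4 (0.22 log units; within the scatter), so losing the hydrogen-bond donor and acceptor counted for hydroxy produces no readable step at this place. The wider exchanges on the same group read alike, with no change at the digits printed from compound 2 to compound 4 (within the scatter) and a 1.8-fold higher number from compound 1 to compound 4 (0.25 log units; within the scatter), and all four compounds remain indistinguishable in this assay. No supporting data bear on this flat reading.

From the compounds shown here alone, whether any group at this place can give a step beyond the scatter in this assay stays open, and an amine or a carboxylic acid in place of chloro would test this. Also open, going by these compounds, is how far the parts of the shared core that stay constant across all four compounds govern the values.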